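The source may report more compounds than this note shows. Statements on the series, on what has been measured and on what is new or still open speak of the compounds shown alone.

Compound 1, `CCCCCCCC/C=C\CCCCCCCCNC(=O)Nc1c(Cl)cc(Cl)cc1Cl`: 1200 nM in an assay on microsomes from intestinal mucosa for inhibition of acyl-CoA:cholesterol acyltransferase (Oryctolagus cuniculus); a lower number here means a stronger inhibitor, a higher number a weaker inhibitor
Compound 2, `CCCCCCCC/C=C\CCCCCCCCNC(=O)Nc1ccc(F)cc1F`: 4700 nM in this assay
Compound 3, `CCCCCCCC/C=C\CCCCCCCCNC(=O)Nc1c(Cl)cccc1Cl`: 400 nM in this assay

Among these three compounds, compound 2 stands highest in this assay, that is, it is the weakest inhibitor of the set. Of the other two, compound 1 lies nearer to it; the step of a 3.9-fold higher number from compound 1 to compound 2 (0.59 log units; beyond the scatter) is modest, while the step of a 12-fold lower number from compound 2 to compound 3 (1.07 log units; beyond the scatter) is large. Both steps alter only the aryl group on the amide-type nitrogen; the unsaturated chain is the same in all three measured compounds.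

Compound 4, `CCCCCCCCCCCCCCNC(=O)Nc1ccc(F)cc1F`, keeps the aryl group of compound 2 and changes the chain instead: hexyl in place of dec-1-en-1-yl on a saturated chain carbon, eight bonds along the chain from an amide-type nitrogen. None of the three measured steps touches this part of the molecule, so the data offer no direct guide to what this change does in this assay. Among the measured compounds shown here, with no comparable step to lean on, the expected step of a 1.1-fold higher number from compound 2 to compound 4 (0.03 log units; within the scatter) is taken to be none beyond the scatter, with a correspondingly wide range around it. Compound 4 is therefore estimated at 5000 nM, with a range from 1500 nM to 16000 nM in this assay.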

Compound 4, half-maximal inhibitory concentration: 340 nM
Compound 4: the middle estimate sits 15-fold (1.17 log units) above what was measured; the measured number lies below the stated range.
By their numbers in this assay, from the lowest: compounds 4 and 3 (each within the scatter of the next); then compound 1; then compound 2.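

Among the compounds shown here, with the 2,4-difluorophenyl group held fixed, this result shows for the first time that the chain also matters in this assay: hexyl in place of dec-1-en-1-yl, on a saturated chain carbon, eight bonds along the chain from an amide-type nitrogen, gives a 14-fold lower number from compound 2 to compound 4 (1.14 log units; beyond the scatter). The earlier steps shown here changed only the aryl group, and this chain change is also large, like the aryl exchange that gives a 12-fold lower number from compound 2 to compound 3 (1.07 log units; beyond the scatter), so the aryl group is not the only part of these ureas on which the number depends. The change removes the double bond and shortens the group at the same time, and nothing in hand explains why the number falls.

The compounds shown leave open whether the double bond or the length of the group accounts for the step, a question that a decyl group at this place would address, since it keeps the carbon count of dec-1-en-1-yl without the double bond. They also leave open whether the same chain change would have a similar effect with the 2,6-dichlorophenyl group of compound 3 or the 2,4,6-trichlorophenyl group of compound 1.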